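Adding a methyl to the aromatic nitrogen of compound 3

The source may report more compounds than this note shows. Statements on the series, on what has been measured and on what is new or still open speak of the compounds shown alone.

Within the data shown here, in a functional assay on MV4-11 cells (Homo sapiens) for inhibition, read by resazurin assay, with a stated time of 72 h (on this read-out higher numbers stand for weaker inhibition of growth and lower numbers for stronger inhibition of growth), compound 3 `COc1ccc(Nc2nccc(-c3c[nH]c4ccccc34)n2)c(OC)c1` gives 600 nM, the lowest of the three numbers so far. Compound 2 `COc1ccc(N(C)c2nccc(-c3cn(C)c4ccccc34)n2)c(OC)c1` gives 2000 nM, and compound 1 `CCn1cc(-c2ccnc(Nc3ccc(OC)cc3OC)n2)c2ccccc21` gives 3590 nM. Compound 4 `COc1ccc(Nc2nccc(-c3cn(C)c4ccccc34)n2)c(OC)c1` has not yet been measured in this assay. It differs from compound 3 by methyl in place of hydrogen on an aromatic nitrogen.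

The closest evidence comes from the same nitrogen, where hydrogen in place of ethyl gave a 6.0-fold lower number from compound 1 to compound 3 (0.78 log units; beyond the scatter), a modest step beyond the scatter. Read backwards, this suggests that a group on that nitrogen raises the number. Compound 2 also carries methyl there, but it differs in a further place, so it is only a loose guide. Methyl is a shorter chain than ethyl, so a somewhat smaller step in the same direction seems likely. The expected step is a 2.2-fold higher number from compound 3 to compound 4 (0.34 log units; beyond the scatter), towards a higher number. For compound 4 the estimated value is 1300 nM, with an expected range from 400 nM to 3500 nM.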

Compound 4, concentration for 50% growth inhibition: 3410 nM
Estimate against measurement, compound 4: 2.6-fold (0.42 log units) below, and the stated range covers the measured number.
By their numbers in this assay, from the lowest: compound 3; then compounds 2, 4 and 1 (each within the scatter of the next).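

In this assay, methyl in place of hydrogen on the aromatic nitrogen gives a 5.7-fold higher number from compound 3 to compound 4 (0.75 log units; beyond the scatter), while hydrogen in place of methyl on the saturated chain carbon gives a 1.1-fold lower number from compound 1 to compound 4 (0.02 log units; within the scatter), so among these compounds the loss comes with methyl and the longer ethyl adds nothing readable. Compound 2 can now be read as well: hydrogen in place of methyl on the nitrogen on an aromatic ring gives a 1.7-fold higher number from compound 2 to compound 4 (0.23 log units; within the scatter), so with methyl on the aromatic nitrogen, that second methyl makes no readable difference. Nothing measured here explains why a group on the aromatic nitrogen raises the number.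

These compounds leave open whether that second methyl would matter with hydrogen on the aromatic nitrogen. They also leave open whether a longer chain ending in an amine or a carboxylic acid on the aromatic nitrogen would behave like methyl and ethyl.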